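Dropping a fluoro group from a fused aromatic core

The source may hold more compounds than are shown below. What is called first, only, known or untested is meant among the compounds shown, and "the series" means these compounds.

Compound 1 `CCCCCNc1nc(NCc2ccco2)c2ccccc2n1` gives "not determined" (no result reported) in a functional assay on MCF7 cells (Homo sapiens) for cytotoxicity, read by MTT assay, with a stated time of 2 days, tested at 10 uM; a lower number here means less inhibition, a higher number more inhibition at the concentration tested (going by the name of the read-out); compound 2 `CCCCNc1nc(NCc2ccco2)c2cc(F)ccc2n1` gives "not determined" (no result reported); compound 3 `CCCCNc1nc(NCc2ccco2)c2cccc(F)c2n1` gives 87%.

Compound 3 thus holds the only number shown, and the other two entries carry no result. Compound 4 `CCCCNc1nc(NCc2ccco2)c2ccccc2n1` differs from compound 3 in one place: hydrogen in place of fluoro on an aromatic carbon. Going by the values given here, no measured pair shows what such a change does in this assay, so the size of the step rests on the structural change alone. A single hydrogen for a fluoro on this ring is expected to shift the read-out by a small amount, most likely downward but plausibly within the scatter, so the expected step is a number 7 percentage points lower from compound 3 to compound 4 (within the scatter). Compound 4 is estimated at 80%, within a range from 60% to 95%.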

Compound 4, a percentage reported as inhibition, at one concentration (the size of the read-out at that concentration, not a potency): 66.7%
Compound 4: the middle estimate sits 13.3 percentage points above what was measured; measured number inside the range.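

In this assay, the fluoro group on this aromatic carbon makes a measurable difference: swapping it for hydrogen gives a number 20.3 percentage points lower from compound 3 to compound 4 (beyond the scatter). Even so, compound 4 still gives 66.7%, so the fluoro group is not needed for substantial inhibition at the tested concentration. Nothing available here explains this drop.

This rests on a single pair of compounds. From the compounds shown here alone, whether a chlorine atom or a methoxy group on the same carbon would keep the read-out nearer that of the fluoro compound remains open.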